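Replacing the aryl group on the ring nitrogen

The source may hold more compounds than are shown below. What is called first, only, known or untested is meant among the compounds shown, and "the series" means these compounds.

Three compounds of the series have numbers in an assay on Sf9 cells for inhibition of protein deacetylase HDAC6 (Homo sapiens), read by fluorescence, with a stated time of 40 min; a higher number here means a weaker inhibitor, a lower number a stronger inhibitor. Compound 3 `Cc1cccc(-n2nc(-c3ccccc3)nc2CNc2ccc(C(=O)NO)cc2)c1` gives 388 nM and stands second highest of the three. Compound 2 `O=C(NO)c1ccc(NCc2nc(-c3ccccc3)nn2-c2ccccc2Cl)cc1` gives 669 nM; the step of a 1.7-fold lower number from compound 2 to compound 3 (0.24 log units; within the scatter) is within the scatter, so these two are not separated. Compound 1 `O=C(NO)c1ccc(NCc2nc(-c3cccs3)nn2-c2ccc(O)cc2)cc1` gives 33.5 nM, a clearly lower number, but compound 1 differs from compound 3 in two places at once, so no single step can be read from it.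

Compound 4 `COc1ccc(-n2nc(-c3ccccc3)nc2CNc2ccc(C(=O)NO)cc2)cc1` is not yet measured. The change from compound 3 is 4-methoxyphenyl in place of 3-methylphenyl on an aromatic nitrogen.

Within the data shown here, only one measured step alters the group on this aromatic nitrogen, and that step, from compound 2 to compound 3, was within the scatter. Among the measured compounds shown here, compound 1, which carries a 4-hydroxyphenyl there alongside a different second ring, is the one compound with a much lower number, but its second difference leaves that open. The expectation for compound 4 is therefore a small movement, if any, toward a lower number, with wide uncertainty. Compound 4 is estimated at 220 nM, between 80 nM and 600 nM, which is an expected step of a 1.8-fold lower number from compound 3 to compound 4 (0.25 log units; within the scatter).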

Compound 4, half-maximal inhibitory concentration: 127 nM
Beside the measured number, compound 4's estimate is 1.7-fold (0.24 log units) above it, within the range that was stated.
By their numbers in this assay, from the lowest: compound 1; then compound 4; then compounds 3 and 2 (each within the scatter of the next).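

The group on the aromatic nitrogen now separates compounds in this series: in this assay, 4-methoxyphenyl in place of 3-methylphenyl gives a step beyond the scatter (a 3.1-fold lower number from compound 3 to compound 4 (0.49 log units; beyond the scatter)), and 4-methoxyphenyl in place of 2-chlorophenyl gives a larger one (a 5.3-fold lower number from compound 2 to compound 4 (0.72 log units; beyond the scatter)). Among these compounds, the only earlier step at this position (a 1.7-fold lower number from compound 2 to compound 3 (0.24 log units; within the scatter)) did not separate its pair, so the position is not indifferent to the aryl group it carries, although both new steps remain modest. Of the three aryl groups compared with the phenyl-bearing core, 4-methoxyphenyl is the only one with an oxygen and a hydrogen-bond acceptor, but no measurement shown explains the lower number of compound 4.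

The 3-methylphenyl and 4-methoxyphenyl groups differ both in the substituent and in where it sits on the ring, so these data cannot assign the step to either difference, and the steps involving compound 1 cannot be read because it differs from the others in two places. Going by these compounds, it also remains open how an amine or a carboxylic acid on this aryl ring would compare with the methoxy group of compound 4.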